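The source may report more compounds than this note shows. Statements on the series, on what has been measured and on what is new or still open speak of the compounds shown alone.

Of the compounds shown here, three built on one shared core have been measured in an assay on isolated protein for inhibition of hexokinase-3 (Rattus norvegicus), with a stated time of 6 h, tested at 10 mM; a higher number here means more inhibition at the concentration tested (going by the name of the read-out), a lower number less inhibition. Compound 1 `O=C(CI)NCCCNc1ncnc2c1ncn2[C@@H]1O[C@H](COP(=O)(O)OP(=O)(O)OP(=O)(O)O)[C@@H](O)[C@H]1O` gives 0%. Compound 2 `O=C(CI)NCCCCCCCCNc1ncnc2c1ncn2[C@@H]1O[C@H](COP(=O)(O)OP(=O)(O)OP(=O)(O)O)[C@@H](O)[C@H]1O` gives 47%. Compound 3 `CN(CCCCN(C)C(=O)CCCNc1ncnc2c1ncn2[C@@H]1O[C@H](COP(=O)(O)OP(=O)(O)OP(=O)(O)O)[C@@H](O)[C@H]1O)C(=O)CCCNC(=O)CI` gives 0%. For the measured compounds named here, only one pair differs in a single place: a number 47 percentage points higher from compound 1 to compound 2 (beyond the scatter). On these numbers compound 2 stands highest of the three, and both compound 1 and compound 3 lie below it by more than the usual scatter.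

Compound 4 `O=C(CI)NCCCC(=O)NCCCCCCNc1ncnc2c1ncn2[C@@H]1O[C@H](COP(=O)(O)OP(=O)(O)OP(=O)(O)O)[C@@H](O)[C@H]1O` differs from compound 2 in one place: a group of 11 heavy atoms (6 carbon, 2 nitrogen, 2 oxygen, 1 iodine; no ring) in place of a group of 7 heavy atoms (4 carbon, 1 nitrogen, 1 oxygen, 1 iodine; no ring), on a saturated chain carbon, six bonds along the chain from a nitrogen on an aromatic ring. Going by the values given here, the only measured step that bears on this is a number 47 percentage points higher from compound 1 to compound 2 (beyond the scatter), where a longer chain carrying the iodine-bearing end strongly raised the read-out. Compound 4 keeps a long chain but adds a second amide within it. Among the compounds with values here, compound 3, whose chain also holds amides, gives 0%, though no single step joins it to compound 2, so this is a weak pointer only. The expected step is therefore a number 22 percentage points lower from compound 2 to compound 4 (beyond the scatter), a moderate fall rather than a rise, with wide uncertainty. Compound 4 is expected to give 25%, within a range from 0% to 55%.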

Compound 4, a percentage reported as inhibition, at one concentration (the size of the read-out at that concentration, not a potency): 0%
Compound 4: middle estimate off by 25 percentage points, on the high side; measured number inside the range.
By their numbers in this assay, from the lowest: compounds 1, 3 and 4 (each within the scatter of the next); then compound 2.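

Within this assay, the longer group that enters at this place, on a saturated chain carbon, six bonds along the chain from a nitrogen on an aromatic ring, gives a number 47 percentage points lower from compound 2 to compound 4 (beyond the scatter) as the result of replacing 2-(((iodomethyl)carbonyl)amino)ethyl. For the compounds shown here, earlier, the only readable step was a gain, a number 47 percentage points higher from compound 1 to compound 2 (beyond the scatter) in this same series, and on its own that step could have suggested that extending the chain simply raises the read-out. The new step shows that this does not hold here: compound 4 keeps the iodine-bearing end and a long chain, with a second amide built into it, yet the read-out is lost.

On these data alone, what stays open is whether the amide inside the chain or the extra chain length accounts for the loss, since the two arrive together in this one change. Going by these compounds alone, an unbroken all-carbon chain as long as the one in compound 4, or a chain with an ether oxygen in place of the amide, would separate these two readings. No outside measurement here offers an explanation for the fall.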